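The source may hold more compounds than are shown below. What is called first, only, known or untested is meant among the compounds shown, and "the series" means these compounds.

Compound 1 `COc1ccccc1NC1=CC(=O)c2c(nc3n2[C@H]2OC[C@@H](O)[C@H]2OC3)C1=O`: in a functional assay on ECa-109 cells for inhibition, with ECa-109 cell line (Homo sapiens) as the target, read by sulforhodamine B assay (on this read-out lower numbers stand for stronger inhibition and higher numbers for weaker inhibition), compound 1 gives > 4000 nM, which is a limit of the assay and not a number.
Compound 2 `CCOc1ccccc1NC1=CC(=O)c2c(nc3n2[C@H]2OC[C@@H](O)[C@H]2OC3)C1=O`: compound 2 gives 4320 nM.
Compound 3 `CCCc1ccc(NC2=CC(=O)c3nc4n(c3C2=O)[C@H]2OC[C@@H](O)[C@H]2OC4)cc1`: compound 3 gives > 4000 nM, again a limit of the assay.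

Among the compounds with values here, compound 2 therefore stands as the only compound of the three with a number in this assay; the other two sit at the limit of > 4000 nM in this assay, at which 2 of the 3 values shown sit. Within the data shown here, the one step between measured neighbours, a step that the limit leaves unreadable from compound 1 to compound 2, cannot be read in size for the same reason, so no measured step tells how changing the group on the amine nitrogen moves the read-out.

Compound 4 `O=C1C(Nc2ccc(Br)cc2)=CC(=O)c2c1nc1n2[C@H]2OC[C@@H](O)[C@H]2OC1` differs from compound 2 in one place: 4-bromophenyl in place of 2-ethoxyphenyl on an amine nitrogen. Among the measured compounds shown here, nothing measured bears on this change; the only evidence is that all three compounds so far lie around the upper edge of what the assay resolves. The expectation is thus no step beyond the scatter, a 1.2-fold higher number from compound 2 to compound 4 (0.06 log units; within the scatter), with a real chance that compound 4 also comes back as a limit. Compound 4 is estimated at 5000 nM, expected to lie between 2000 nM and 20000 nM.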

Compound 4, half-maximal inhibitory concentration: 1980 nM
For compound 4 the middle estimate is 2.5-fold (0.40 log units) above the measured one; the whole stated range lies above it.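

Within the data shown here, on the amine nitrogen, 4-bromophenyl in place of 2-ethoxyphenyl gives the first step that can be read in this assay, a 2.2-fold lower number from compound 2 to compound 4 (0.34 log units; beyond the scatter). Among these compounds, the step is modest, but it shows that the group on this nitrogen can move the read-out on the shared core, which the earlier compounds could not show. The comparison of 4-bromophenyl with 2-methoxyphenyl gives an at least 2.0-fold lower number from compound 1 to compound 4 (0.30 log units; that floor lies within the scatter), so it adds only a floor, and much of the series still sits at the top of what the assay resolves: the limit of > 4000 nM in this assay, at which 2 of the 4 values shown sit.

The compounds shown leave open whether the step belongs to the bromine itself, to the loss of the 2-ethoxy group, or to both together. They also leave open how a chlorophenyl, a pyridine ring or a longer alkyl chain on this nitrogen would read in this assay, and whether any such group would carry the number clearly further down from that of compound 4.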